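A larger group on the amide-type nitrogen of compound 2

The source may hold more compounds than are shown below. What is called first, only, known or untested is meant among the compounds shown, and "the series" means these compounds.

Compound 1 `Cc1cc(=O)oc2cc(OCC(=O)NN)ccc12` gives 8.05 nM
Compound 2 `Cc1c(C)c2ccc(OCC(=O)NN)cc2oc1=O` gives 9.14 nM
Compound 3 `Cc1c(C)c2ccc(OCc3nnc(S)s3)cc2oc1=O` gives 9.55 nM

All three values come from a functional assay on the whole organism (strain Wistar) for inhibition, with Rattus norvegicus as the target, with a stated time of 4 h (on this read-out higher numbers stand for an effect only at larger amounts of compound and lower numbers for an effect already at smaller amounts), and sit close together. Compound 2, at 9.14 nM, has both compound 1 and compound 3 within the scatter of it. Compound 4 `Cc1c(C)c2ccc(OCC(=O)N/N=C/c3ccc(Cl)cc3)cc2oc1=O` is not yet measured. It departs from compound 2 on an amide-type nitrogen whose other neighbour is a carbonyl carbon, and the change is a group of 9 heavy atoms (7 carbon, 1 nitrogen, 1 chlorine; one six-membered aromatic ring of carbon only) in place of one nitrogen atom, on an amide-type nitrogen in this one place.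

For the measured compounds named here, two measured steps bear on it. The closer one, a 1.0-fold higher number from compound 2 to compound 3 (0.02 log units; within the scatter), replaces aminocarbamoyl with 5-sulfanyl-1,3,4-thiadiazol-2-yl in the same side chain and leaves the number where it was. The other, a 1.1-fold higher number from compound 1 to compound 2 (0.06 log units; within the scatter), puts methyl in place of hydrogen on an aromatic carbon, elsewhere in the molecule. Neither step reaches beyond the scatter. Going by the values given here, no measured compound carries a six-membered aromatic ring of carbon only on that nitrogen, so the guide is weak and the range must stay wide. The expected change is a 1.0-fold higher number from compound 2 to compound 4 (0.02 log units; within the scatter) and thus none beyond the scatter in either direction. In this assay compound 4 is expected at 9.5 nM with an estimated range from 4.5 nM to 20 nM for a single measurement.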

Compound 4, concentration for half-maximal effect: 74.6 nM
Compound 4: the middle estimate sits 7.9-fold (0.90 log units) below what was measured; measured number outside the range, above it.
By their numbers in this assay, from the lowest: compounds 1, 2 and 3 (each within the scatter of the next); then compound 4.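

In this assay, for the compounds shown here, the amide-type nitrogen is the first place in this set where a change moves the number beyond the scatter: an 8.2-fold higher number from compound 2 to compound 4 (0.91 log units; beyond the scatter) comes with the entry of the group of 9 heavy atoms, with its six-membered aromatic ring of carbon only, in place of one nitrogen atom. The side chain does not respond alike to every replacement, since the change to 5-sulfanyl-1,3,4-thiadiazol-2-yl gives only a 1.0-fold higher number from compound 2 to compound 3 (0.02 log units; within the scatter) and remains within the scatter. The data shown offer no measurement that explains why this one replacement has the larger effect.

On these data alone, it remains open whether the step belongs to the chlorine, the aromatic ring or the double bond outside aromatic rings, and how a methoxy group in place of the chlorine, or a single methyl group on that nitrogen, would read. Also open, as far as these compounds go, is whether the same entering group would give a step of similar size on the core of compound 1, which lacks the extra methyl group.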